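A longer ester chain on compound 2

The source may hold more compounds than are shown below. What is called first, only, known or untested is meant among the compounds shown, and "the series" means these compounds.

Compound 1 `COCCn1c2ccc([N+](=O)[O-])cc2c(=O)n1Cc1ccccc1`: > 256000 nM
Compound 2 `COC(=O)COc1c2cc([N+](=O)[O-])ccc2nn1Cc1ccccc1`: > 256000 nM

Both compounds were tested in an ADME assay on L929 cells (Mus musculus) for cytotoxicity, read by resazurin assay, with a stated time of 48 h; a lower number here means that less compound is tolerated, a higher number that more compound is tolerated. Compound 1 gives > 256000 nM, which is a limit of the assay and not a number. Compound 2 gives > 256000 nM, which is also only a limit. Compound 2 therefore has no numerical value, and the record so far shows (the limit of > 256000 nM in this assay, at which 2 of the 2 values shown sit).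

Compound 3 `CCOC(=O)CCCOc1c2cc([N+](=O)[O-])ccc2nn1Cc1ccccc1` keeps the core of compound 2 and differs in one place: 2-(ethoxycarbonyl)ethyl in place of methoxycarbonyl on a saturated chain carbon bound to an oxygen on an aromatic ring. Here 2-(ethoxycarbonyl)ethyl stands in place of methoxycarbonyl on a saturated chain carbon bound to an oxygen on an aromatic ring. Read one bond further out, (methoxycarbonyl)methoxy becomes 3-(ethoxycarbonyl)propoxy.

For the measured compounds named here, no measured pair shows what such a change does in this assay, and a limit offers no exact starting point. No step beyond the scatter is expected, and any shift that does appear is expected to be towards less compound being tolerated. The expected change is an at least 1.1-fold lower number from compound 2 to compound 3 (0.06 log units; that floor lies within the scatter). For compound 3 the estimated value is 220000 nM, within an expected range of 100000 nM to 400000 nM.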

Compound 3, concentration lethal to 50% of the cells: > 256000 nM
Compound 3: only a limit was reported; the forecaster's own chance of this, stated with the estimate: 60%; at least 1.1-fold (0.06 log units) between middle value and limit.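

Compound 2 and compound 3 both give only a limit, not a number, in this assay, so no step between them can be read: the limit of > 256000 nM in this assay, at which 3 of the 3 values shown sit.

The compounds shown leave open where each true value lies, and whether 2-(ethoxycarbonyl)ethyl in place of methoxycarbonyl changes how much compound is tolerated.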